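A few compounds are considered here, and "the series" means these few. Any claim that something is new, unique, unknown or untested is made for them only; others in the source may bear on it.

Of the compounds shown here, two from this series have been measured in a functional assay on CLL cells (Homo sapiens) for cytotoxicity, read by MTT assay, with a stated time of 48 h; on this read-out lower numbers stand for an effect already at smaller amounts and higher numbers for an effect only at larger amounts of compound. Compound 1 `C=C(CC)C(=O)c1ccc(OCC(=O)Nc2ccc(C(=O)O)cn2)c(Cl)c1Cl` gives 14900 nM in this assay, which is the highest of the two numbers. Compound 2 `C=C(CC)C(=O)c1ccc(OCC(=O)Nc2ccc(C(=O)NC(CCC(=O)OCC)C(=O)OCC)cc2)c(Cl)c1Cl` gives 2100 nM in this assay, a number that lies beyond the scatter below that of compound 1; as the two differ in more than one place, only their two values can be compared, not the step itself.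

Compound 3 `C=C(CC)C(=O)c1ccc(OCC(=O)NCO[N+](=O)[O-])c(Cl)c1Cl` has not been measured. It differs from compound 1 in one place: (nitrooxy)methyl in place of 5-carboxypyridin-2-yl on an amide-type nitrogen. For the measured compounds named here, no measured pair shows the effect of such a change, so the expectation for compound 3 rests only on the values of compound 1 and compound 2. A modest step from compound 1 to compound 3 is expected, a 1.5-fold lower number from compound 1 to compound 3 (0.17 log units; within the scatter), with no firm direction. Compound 3 is therefore expected to give 10000 nM in this assay, within a range of 3000 nM to 30000 nM.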

Compound 3, half-maximal effective concentration: 4100 nM
The estimate for compound 3 lay 2.4-fold (0.39 log units) above the measured number; measured number inside the range.
By their numbers in this assay, from the lowest: compounds 2 and 3 (each within the scatter of the next); then compound 1.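

Replacing the substituent on the amide-type nitrogen moves the number in this assay beyond the scatter, and the step is a 3.6-fold lower number from compound 1 to compound 3 (0.56 log units; beyond the scatter), with (nitrooxy)methyl in place of 5-carboxypyridin-2-yl. For the compounds shown here, this is the first reading of a single change at this position, and it shows that the six-membered aromatic ring and its carboxylic acid can be given up here without a rise in the number. No measurement available bears on why the number falls, so the step cannot be assigned to what leaves or to what enters.

Going by these compounds alone, the one step removes the ring and adds the nitrooxy group together, so their separate shares remain open. A plain methyl or hydroxymethyl on this nitrogen, or a longer chain ending in the nitrooxy group, would separate those shares and test the length of the link.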